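A few compounds are considered here, and "the series" means these few. Any claim that something is new, unique, unknown or untested is made for them only; others in the source may bear on it.

Measured compounds:
compound 1, `O=C(CSC(=S)N[C@H]1CCOC1=O)Nc1ccc(Br)cc1`: 67400 nM
compound 2, `O=C(CSC(=S)N[C@H]1CCOC1=O)Nc1ccccc1`: a limit of the assay
compound 3, `O=C(CCl)Nc1ccc(C(=O)/C=C/c2ccccc2)cc1`: 6370 nM

All three were tested in a functional assay on EC9706 cells (Homo sapiens) for cytotoxicity, read by MTT assay, with a stated time of 72 h; a higher number here means a weaker inhibitor, a lower number a stronger inhibitor. Compound 1 gives 67400 nM. In this assay compound 2 gives > 128000 nM, which is a limit of the assay and not a number; (the limit of > 128000 nM in this assay, at which 1 of the 3 values shown sits). Compound 3 gives 6370 nM, the lower of the two numbers that were read, and the gap between it and compound 1 lies beyond the usual scatter.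

Compound 1 and compound 2 share a core and differ in one place only: bromo in place of hydrogen on an aromatic carbon. This change gives an at least 1.8-fold lower number from compound 2 to compound 1 (0.27 log units; that floor lies within the scatter), a step whose floor lies within the scatter, so it is a small step at most, though it may be larger.

Compound 3 has a different core, and how that core differs from the core of compound 2 is not broken down here.

The compound still to be measured is compound 4, `O=C(CCl)Nc1ccc(C(=O)/C=C/c2ccc(Br)cc2)cc1`. It differs from compound 3 in one place: bromo in place of hydrogen on an aromatic carbon. The place is worded the same as for the step from compound 2 to compound 1, so this is the same change, now made on the core of compound 3.

For compound 4 the expected step is a 1.4-fold lower number from compound 3 to compound 4 (0.15 log units; within the scatter), set beside an at least 1.8-fold lower number from compound 2 to compound 1 (0.27 log units; that floor lies within the scatter), because that step, the only one shown for this change, points to a number that is similar or slightly lower. The estimate for compound 4 is therefore 4500 nM, expected to fall between 2000 nM and 10000 nM.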

Compound 4, half-maximal inhibitory concentration: 10100 nM
Beside the measured number, compound 4's estimate is 2.2-fold (0.35 log units) below it; the measured number lies above the stated range.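

Carried to the other core, bromo in place of hydrogen gives a 1.6-fold higher number from compound 3 to compound 4 (0.20 log units; within the scatter) in this assay, so on this core the swap from phenyl to 4-bromophenyl produces no shift that can be told apart from the ordinary spread of repeat measurements. Set beside the earlier step, this result shows that the change does not carry over as one fixed shift from one core to the other: the same change on two cores in this assay, an at least 1.8-fold lower number (0.27 log units; that floor lies within the scatter) from compound 2 to compound 1 and a 1.6-fold higher number (0.20 log units; within the scatter) from compound 3 to compound 4, at least 3.0-fold (0.47 log units) apart, beyond the scatter of two such steps. From the compounds shown here alone, compound 2 gives > 128000 nM, a limit of the assay and not a number, so the full size of the earlier step stays unknown, and two pairs of compounds show neither why the two cores part nor how a third core would respond.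

Only hydrogen and bromo are compared here, which leaves open whether fluoro, chloro, methoxy or an amine at the same place would follow the pattern of either core. Also open is how far the number would move if the chlorine-bearing end of compound 3 and compound 4 were replaced, for example by an amine, since every comparison shown changes only the aromatic ring.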